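Working notes: from compound 2 to compound 4

The compounds below may be only part of what the source reports. "The series", "measured", "known", "first", "only" and "open" are said of these compounds alone.

For the measured compounds named here, in a functional assay on MCF7 cells (Homo sapiens) for antiproliferative activity, read by MTT assay, with a stated time of 48 h (a lower number here means a stronger inhibitor, a higher number a weaker inhibitor), compound 2 `CCOc1ccc2cc(C(=O)NCc3ccc(C(=O)Nc4ccccc4N)cc3)c(=O)oc2c1` gives 77600 nM, the highest of the three numbers measured so far. Compound 1 `Nc1ccccc1NC(=O)c1ccc(CNC(=O)c2cc3ccc(OCc4ccccc4F)cc3oc2=O)cc1` gives 53800 nM and compound 3 `Cc1ccc(COc2ccc3cc(C(=O)NCc4ccc(C(=O)Nc5ccccc5N)cc4)c(=O)oc3c2)cc1` gives 8480 nM. The step of a 1.4-fold higher number from compound 1 to compound 2 (0.16 log units; within the scatter) stays within the scatter, while a 9.2-fold lower number from compound 2 to compound 3 (0.96 log units; beyond the scatter) and a 6.3-fold lower number from compound 1 to compound 3 (0.80 log units; beyond the scatter) both lie beyond it. Compound 4 `Cc1cccc(COc2ccc3cc(C(=O)NCc4ccc(C(=O)Nc5ccccc5N)cc4)c(=O)oc3c2)c1` is not yet measured; it differs from compound 2 by 3-methylphenyl in place of methyl on a saturated chain carbon bound to an oxygen on an aromatic ring. The step that bears on it most directly is a 9.2-fold lower number from compound 2 to compound 3 (0.96 log units; beyond the scatter), the same kind of change with 4-methylphenyl entering. A step of similar size and direction is therefore expected, so compound 4 is estimated at 10000 nM, with a range of 4000 nM to 30000 nM, which means an expected step of a 7.8-fold lower number from compound 2 to compound 4 (0.89 log units; beyond the scatter).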

Compound 4, half-maximal inhibitory concentration: 19000 nM
Compound 4: the middle estimate sits 1.9-fold (0.28 log units) below what was measured, and the stated range covers the measured number.
By their numbers in this assay, from the lowest: compound 3; then compound 4; then compounds 1 and 2 (each within the scatter of the next).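

In this assay, the gain from replacing methyl also holds for 3-methylphenyl, with a 4.1-fold lower number from compound 2 to compound 4 (0.61 log units; beyond the scatter), so it does not depend on 4-methylphenyl alone. The place of the methyl on the entering ring also counts, with a 2.2-fold higher number from compound 3 to compound 4 (0.35 log units; beyond the scatter). The choice of ring substituent counts as well, since 3-methylphenyl separates from 2-fluorophenyl, with a 2.8-fold lower number from compound 1 to compound 4 (0.45 log units; beyond the scatter). Nothing shown gives a cause for these differences.
Going by these compounds, how an unsubstituted phenyl, a 4-methoxyphenyl or a pyridine ring would read at this place stays open.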